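Extending the chain beyond compound 1

This account rests on a few compounds, and the source may have more. Where it says the series, first, only, none or still open, it means among the compounds named here.

Compound 1 `COc1ccc(N(C)c2nc(C)nc3ccccc23)cc1OCCC[Se]C#N`: 1040 nM
Compound 2 `COc1ccc(N(C)c2nc(C)nc3ccccc23)cc1OCC[Se]C#N`: 14 nM

Within the data shown here, in a functional assay on HepG2 cells (Homo sapiens) for inhibition, read by MTT assay, with a stated time of 48 h (on this read-out lower numbers stand for stronger inhibition and higher numbers for weaker inhibition), compound 1 gives 1040 nM, the higher of the two numbers so far. Compound 3 `COc1ccc(N(C)c2nc(C)nc3ccccc23)cc1OCCCC[Se]C#N` has not been measured yet. It differs from compound 1 by one change: a group of 4 heavy atoms (2 carbon, 1 nitrogen, 1 selenium; no ring) in place of a group of 3 heavy atoms (1 carbon, 1 nitrogen, 1 selenium; no ring), on a saturated chain carbon, three bonds along the chain from an oxygen on an aromatic ring.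

Among the measured compounds shown here, only one measured step bears on this change: a 74-fold lower number from compound 1 to compound 2 (1.87 log units; beyond the scatter). That step is large, and it goes to the smaller group, while compound 3 carries the larger one. Going by a 74-fold lower number from compound 1 to compound 2 (1.87 log units; beyond the scatter), a higher number is expected in this assay. A single step cannot fix the size, so a smaller move is assumed, and the range is kept wide. The expected move is a 2.4-fold higher number from compound 1 to compound 3 (0.38 log units; beyond the scatter).

For compound 3 the estimated value is 2500 nM, with an expected range of 250 nM to 15000 nM.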

Compound 3, half-maximal inhibitory concentration: 6460 nM
Beside the measured number, compound 3's estimate is 2.6-fold (0.41 log units) below it; low and high end bracket the measured number.
By their numbers in this assay, from the lowest: compound 2; then compound 1; then compound 3.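

In this assay, lengthening the chain past compound 1 pushes the number further up (a 6.2-fold higher number from compound 1 to compound 3 (0.79 log units; beyond the scatter)), so the weakening seen on going from the chain of compound 2 to that of compound 1 does not stop at compound 1. The full span of the series is wide (a 460-fold higher number from compound 2 to compound 3 (2.66 log units; beyond the scatter)), and among these three compounds the number rises with each added chain carbon, with none going against that order. No measurement at hand explains why chain length matters so much here.

Still open, from the compounds shown here alone, is whether a chain shorter than that of compound 2 would give an even lower number, or a chain longer than that of compound 3 a higher one. Going by these compounds, it is also open whether the same trend would hold with an amine or a carboxylic acid at the chain end in place of the selenium and nitrile.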